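Thioether series: naphthalen-1-yl on sulfur

A few compounds are considered here, and "the series" means these few. Any claim that something is new, unique, unknown or untested is made for them only; others in the source may bear on it.

- Compound 1 `COc1ccc(SCc2ccc(/C=C/C(=O)Nc3ccccc3N)cc2)cc1OC`: 49.5%
- Compound 2 `Nc1ccccc1NC(=O)/C=C/c1ccc(CSc2ccc(F)cc2)cc1`: 20.2%

In a functional assay on HCT-116 cells (Homo sapiens) for inhibition, read by CCK-8 assay, with a stated time of 72 h, tested at 8 uM (a lower number here means less inhibition of growth, a higher number more inhibition of growth at the concentration tested), compound 2 is the lower of the two measured compounds. Going by the values given here, the only measured step bearing on the next change is a number 29.3 percentage points lower from compound 1 to compound 2 (beyond the scatter), a modest one, beyond the scatter, made at the same sulfur. Compound 3 `Nc1ccccc1NC(=O)/C=C/c1ccc(CSc2cccc3ccccc23)cc1` carries naphthalen-1-yl in place of 4-fluorophenyl on a sulfur. That single step involves different groups, so it gives only weak guidance on direction. A small rise in this assay is expected, perhaps not clearing the scatter. The expected step is a number 11.8 percentage points higher from compound 2 to compound 3 (beyond the scatter). Compound 3 is estimated at 32%, with an expected range of 10% to 55%.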

Compound 3, percent growth inhibition at one concentration: 35.2%
Estimate against measurement, compound 3: 3.2 percentage points below; the measured number falls inside the stated range.
By their numbers in this assay, from the lowest: compound 2; then compound 3; then compound 1.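

In this assay the group on the sulfur keeps moving the read-out: naphthalen-1-yl gives a number 15 percentage points higher from compound 2 to compound 3 (beyond the scatter) and also a number 14.3 percentage points lower from compound 1 to compound 3 (beyond the scatter) in the comparison with 3,4-dimethoxyphenyl. A group of carbon only, with 2 six-membered aromatic rings, therefore regains part of the gap left by 4-fluorophenyl, while 3,4-dimethoxyphenyl remains the highest of the three. Nothing measured here accounts for this order. Still open, from the compounds shown here alone, is how an amine or a carboxylic acid on the aromatic ring attached to the sulfur would rank against these three groups.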